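Trading Fluoro for Methyl on the Phenyl Ring

A few compounds are considered here, and "the series" means these few. Any claim that something is new, unique, unknown or untested is made for them only; others in the source may bear on it.

Measured so far in an assay for binding affinity to dual specificity mitogen-activated protein kinase kinase 4 (Homo sapiens), read by KINOMEscan, tested at 100 nM; on this read-out lower numbers stand for a stronger effect and higher numbers for a weaker effect at the one concentration tested:
Compound 1 `CCCS(=O)(=O)Nc1ccc(F)c(C(=O)c2n[nH]c3ncc(-c4ccccc4)cc23)c1F` gives 2.4%.
Compound 2 `CCCS(=O)(=O)Nc1ccc(F)c(C(=O)c2n[nH]c3ncc(-c4ccccc4Cl)cc23)c1F` gives 9.3%.
Compound 3 `CCCS(=O)(=O)Nc1ccc(F)c(C(=O)c2n[nH]c3ncc(-c4ccccc4F)cc23)c1F` gives 2%.

Compound 3 has the lowest of these three numbers, yet the steps that lead to it are a number 0.4 percentage points lower from compound 1 to compound 3 (within the scatter) and a number 7.3 percentage points lower from compound 2 to compound 3 (within the scatter), so all three sit within the scatter of one another and none can be called the strongest. Compound 4 `CCCS(=O)(=O)Nc1ccc(F)c(C(=O)c2n[nH]c3ncc(-c4ccccc4C)cc23)c1F` differs from compound 3 by methyl in place of fluoro on an aromatic carbon, the same difference cut one bond further out reading 2-fluorophenyl to 2-methylphenyl. For the measured compounds named here, no measured step swaps fluoro for methyl; the nearest are hydrogen to fluoro, a number 0.4 percentage points lower from compound 1 to compound 3 (within the scatter), and chloro to fluoro, a number 7.3 percentage points lower from compound 2 to compound 3 (within the scatter), both within the scatter. For compound 4 a step within the scatter is expected in this assay, a number 2 percentage points higher from compound 3 to compound 4 (within the scatter). Compound 4 is estimated at 4%, between 1% and 12%.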

Compound 4, a percentage reported as activity, at one concentration (the size of the read-out at that concentration, not a potency): 7%
For compound 4 the middle estimate is 3 percentage points below the measured one; measured number inside the range.
By their numbers in this assay, from the lowest: compounds 3, 1, 4 and 2 (each within the scatter of the next).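

Methyl on this aromatic carbon adds a carbon group to the halogens and hydrogen already seen there, and in this assay the steps read a number 5 percentage points higher from compound 3 to compound 4 (within the scatter), a number 2.3 percentage points lower from compound 2 to compound 4 (within the scatter) and a number 4.6 percentage points higher from compound 1 to compound 4 (within the scatter). All four groups therefore stay within the scatter of one another, so this single concentration does not separate them. No evidence here explains this result. On these data alone, whether an amine, a carboxylic acid or a longer chain at this position would stand apart from these four remains open.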